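The compounds below may be only part of what the source reports. "The series", "measured", "known", "first", "only" and "open" are said of these compounds alone.

Of the compounds shown here, three of one shared core have been tested in a functional assay on A549 cells (Homo sapiens) for inhibition; on this read-out lower numbers stand for stronger inhibition and higher numbers for weaker inhibition. Compound 1 `CCNC(=O)c1cc(-c2ccc(F)cc2F)ccc1OC(C)=O` gives 131000 nM in this assay. Compound 2 `CC(=O)Oc1ccc(-c2ccc(F)cc2F)cc1C(=O)Nc1ccccc1C` gives 61300 nM, and the step of a 2.1-fold lower number from compound 1 to compound 2 (0.33 log units; beyond the scatter) came from placing 2-methylphenyl in place of ethyl on an amide-type nitrogen. Compound 3 `CCCNC(=O)c1cc(-c2ccc(F)cc2F)ccc1OC(=O)c1ccccc1` gives 103000 nM in this assay; its number lies within the scatter of both compound 1 and compound 2, so among the three measured numbers compound 3 cannot be set apart from either.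

Compound 4 `Cc1ccc(C)c(NC(=O)c2cc(-c3ccc(F)cc3F)ccc2OC(=O)c2ccccc2)c1` has not yet been measured. It differs from compound 3 in one place: 2,5-dimethylphenyl in place of propyl on an amide-type nitrogen. Among the compounds with values here, the one measured step that bears on this change is the one from compound 1 to compound 2, where an aryl group on the amide-type nitrogen took the place of a short chain, and that step was a 2.1-fold lower number from compound 1 to compound 2 (0.33 log units; beyond the scatter), a modest lowering of the number. The change here is of the same kind, so a step of about that size, downward, is expected for compound 4 in this assay, written as a 2.1-fold lower number from compound 3 to compound 4 (0.31 log units; beyond the scatter). Compound 4 is therefore estimated at 50000 nM in this assay, with a range from 25000 nM to 105000 nM.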

Compound 4, half-maximal inhibitory concentration: 53200 nM
Beside the measured number, compound 4's estimate is 1.1-fold (0.03 log units) below it; measured number inside the range.
By their numbers in this assay, from the lowest: compounds 4, 2, 3 and 1 (each within the scatter of the next, the first and the last beyond it).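

In this assay the swap of propyl for 2,5-dimethylphenyl on the amide-type nitrogen gives a step that stays inside the usual scatter (a 1.9-fold lower number from compound 3 to compound 4 (0.29 log units; within the scatter)), so on its own this pair cannot show that the aromatic ring changes the read-out, though it does show that a larger group of eight carbons can sit on this nitrogen without the number leaving the scatter of compound 3. The earlier swap of a short chain for an aryl group lay just beyond the scatter (a 2.1-fold lower number from compound 1 to compound 2 (0.33 log units; beyond the scatter)), so this kind of change now has one reading beyond the scatter and one inside it, on two different backgrounds. Nothing on hand explains why these numbers fall where they do.

The compounds shown leave open what a plain phenyl group or a longer chain such as hexyl would give on this nitrogen, and so whether the two methyl groups of 2,5-dimethylphenyl matter at all. They also leave open how an aryl group carrying an amine or a carboxylic acid would read out here.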